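Working notes: compound 4 ahead of its measurement

This account rests on a few compounds, and the source may have more. Where it says the series, first, only, none or still open, it means among the compounds named here.

Measured so far in a functional assay on PC-3 cells (Homo sapiens) for inhibition, with a stated time of 72 h; a lower number here means a stronger inhibitor, a higher number a weaker inhibitor: compound 1 `COc1ccc(NC(=O)Nc2nc(Sc3c[nH]c4ccccc34)cc(N3CCCCC3)n2)cc1` gives 17400 nM; compound 2 `COc1ccc(NC(=O)Nc2nc(Sc3c[nH]c4ccccc34)cc(N3CCN(c4ccccn4)CC3)n2)cc1` gives 33400 nM; compound 3 `O=C(Nc1ccccc1)Nc1nc(Sc2c[nH]c3ccccc23)cc(N2CCN(Cc3ccccc3)CC2)n1` gives 42500 nM.

Compound 2 sits between the other two numbers, close to compound 3 and somewhat further from compound 1. For the measured compounds named here, the only step that touches the same position is a 1.9-fold higher number from compound 1 to compound 2 (0.28 log units; within the scatter), which stayed within the scatter. Compound 4 `COc1ccc(NC(=O)Nc2nc(Nc3cc(OC)cc(OC)c3)cc(Sc3c[nH]c4ccccc34)n2)cc1` carries a different kind of group there: (3,5-dimethoxyphenyl)amino in place of 4-(pyridin-2-yl)piperazin-1-yl on an aromatic carbon. Going by the values given here, no measured step brings in an aromatic amino group at this position, so the basis for expecting a shift is thin. The estimate is therefore a step of a 1.1-fold lower number from compound 2 to compound 4 (0.05 log units; within the scatter) in this assay , no larger than the scatter. Compound 4 is expected to give about 30000 nM, within 9000 nM to 100000 nM.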

Compound 4, half-maximal inhibitory concentration: 15100 nM
Estimate against measurement, compound 4: 2.0-fold (0.30 log units) above, within the range that was stated.
By their numbers in this assay, from the lowest: compounds 4, 1, 2 and 3 (each within the scatter of the next, the first and the last beyond it).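

In this assay, this position now gives a step beyond the scatter, a 2.2-fold lower number from compound 2 to compound 4 (0.34 log units; beyond the scatter), whereas the earlier step here stayed within it. (3,5-Dimethoxyphenyl)amino, with its hydrogen-bond donor and aromatic ring of carbon only, stands level with piperidin-1-yl, at a 1.2-fold lower number from compound 1 to compound 4 (0.06 log units; within the scatter). Nothing available explains either step.

The compounds shown leave open whether the amino link or the two methoxy groups matter more for the step. From the compounds shown here alone, how an unsubstituted phenylamino group or a morpholin-4-yl group would read at this position also remains open.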